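A few compounds are considered here, and "the series" means these few. Any claim that something is new, unique, unknown or untested is made for them only; others in the source may bear on it.

Of the compounds shown here, three built on a shared core have been measured. Compound 1 `CCC(CC)Nc1nc(C)nc2c1nnn2-c1c(C)cc(C)cc1C`, compound 2 `CCN(CC)c1nc(C)nc2c1nnn2-c1ccc(C(C)C)cc1Br` and compound 3 `CCCCN(CC)c1nc(C)nc2c1nnn2-c1ccc(C(C)=O)cc1Br` were tested in an in vitro assay on 293-EBNA cells for binding affinity to corticotropin-releasing factor receptor 1 (Homo sapiens); on this read-out higher numbers stand for weaker inhibition and lower numbers for stronger inhibition. In this assay compound 1 gives 5.7 nM, compound 2 gives 25.3 nM and compound 3 gives 33.7 nM. Among these three numbers compound 2 stands second highest; its nearest neighbour is compound 3, whose number lies within the usual scatter of that of compound 2, so the two cannot be told apart, while compound 1 sits furthest away, beyond the scatter, with the lower number of the pair.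

Compound 4 `CCOCC(COCC)Oc1nc(C)nc2c1nnn2-c1ccc(C(C)C)cc1Br` has not yet been measured. It differs from compound 2 in a single place: a group of 10 heavy atoms (7 carbon, 3 oxygen; no ring) in place of a group of 5 heavy atoms (4 carbon, 1 nitrogen; no ring), on an aromatic carbon. Among the measured compounds shown here, no pair of measured compounds shows a change of this kind, so no step is on record to guide the expectation, which therefore rests on the number of compound 2 in this assay, 25.3 nM, and on the size of the substitution. A modest weakening, at the edge of the scatter or slightly beyond it, is expected. Compound 4 is expected to give 60 nM in this assay, within a range from 15 nM to 250 nM. This estimate means an expected step of a 2.4-fold higher number from compound 2 to compound 4 (0.38 log units; beyond the scatter).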

Compound 4, inhibition constant: 39.7 nM
Compound 4: middle estimate off by 1.5-fold (0.18 log units), on the high side, and the stated range covers the measured number.
By their numbers in this assay, from the lowest: compound 1; then compounds 2, 3 and 4 (each within the scatter of the next).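

In this assay, replacing the diethylamino group on this aromatic carbon, next to the ring nitrogen, with a group of 10 heavy atoms (7 carbon, 3 oxygen; no ring) gives a 1.6-fold higher number from compound 2 to compound 4 (0.20 log units; within the scatter). Among the compounds shown here, this is the first step on record at this position, and it shows that a group attached through oxygen, with 3 hydrogen-bond acceptors in place of 1, can stand here without a difference beyond the scatter. No measurement on record explains this result.

From the compounds shown here alone, it remains open whether a small methoxy group or a ring such as morpholine at this position would also stay within the scatter of compound 2. Going by these compounds, compound 1 and compound 3 differ from compound 4 in more than one place, so it is also open whether this change would give a similar step alongside the other groups they carry.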